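Replacing the group on sulfur in compound 2

This account rests on a few compounds, and the source may have more. Where it says the series, first, only, none or still open, it means among the compounds named here.

Compound 1 `CCc1ccc(SCc2ccc(C(=O)Nc3ccccc3N)cc2)cc1`: 79.1%
Compound 2 `Nc1ccccc1NC(=O)c1ccc(CSc2ccc(Cl)cc2)cc1`: 76.6%

Both compounds were tested in a functional assay on HCT-116 cells (Homo sapiens) for inhibition, read by CCK-8 assay, with a stated time of 72 h, tested at 8 uM; on this read-out lower numbers stand for less inhibition of growth and higher numbers for more inhibition of growth at the one concentration tested. Compound 2, at 76.6%, lies within the scatter of compound 1, so the two cannot be ranked. Compound 3 `Cc1cc(C)cc(SCc2ccc(C(=O)Nc3ccccc3N)cc2)c1` has not yet been measured. It carries 3,5-dimethylphenyl in place of 4-chlorophenyl on a sulfur.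

Among the measured compounds shown here, only one measured step bears on this change, with chloro in place of ethyl on an aromatic carbon: a number 2.5 percentage points lower from compound 1 to compound 2 (within the scatter). For the measured compounds named here, that step was small, but it is a single and only partial guide, since no measured compound carries 3,5-dimethylphenyl. No shift beyond the scatter is therefore expected in this assay, and no firm direction can be given. The expected change is a number 2.6 percentage points lower from compound 2 to compound 3 (within the scatter). For compound 3 the estimated value is 74%, with an expected range of 58% to 86%.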

Compound 3, percent growth inhibition at one concentration: 72.9%
The estimate for compound 3 lay 1.1 percentage points above the measured number; measured number inside the range.
By their numbers in this assay, from the lowest: compounds 3, 2 and 1 (each within the scatter of the next).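

The earlier pair had only exchanged one group on the aromatic ring for another. Here the whole group on sulfur changes, and in this assay this gives a number 3.7 percentage points lower from compound 2 to compound 3 (within the scatter) and, with 4-ethylphenyl as the group that gives way, a number 6.2 percentage points lower from compound 1 to compound 3 (within the scatter). The place on sulfur has now held 3,5-dimethylphenyl as well as 4-chlorophenyl and 4-ethylphenyl, and no exchange among these three moves the number beyond the scatter. Nothing measured here offers a reason for this.

From the compounds shown here alone, whether the same holds for an aromatic ring bearing an amine or a carboxylic acid, or for cyclohexyl on the sulfur, stays open. Going by these compounds, all three compounds also rest on a single concentration in this assay, so how they compare at other concentrations is unknown.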